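Acetyl series: pyridin-2-yl for pyrimidin-2-yl

A few compounds are considered here, and "the series" means these few. Any claim that something is new, unique, unknown or untested is made for them only; others in the source may bear on it.

Values in a functional assay on L5178Y cells (Mus musculus) for cytotoxicity, read by MTT assay (on this read-out lower numbers stand for stronger inhibition and higher numbers for weaker inhibition), so far:
compound 1 `CC(=O)c1ccc(OCCCCN2CCN(c3cccnc3)CC2)cc1` gives 69 nM
compound 2 `CC(=O)c1ccc(OCCCCN2CCN(c3ncccn3)CC2)cc1` gives > 100 nM as a limit
compound 3 `CC(C)(C)c1ccc(OCCCCN2CCN(c3ncccn3)CC2)cc1` gives 20.8 nM

Compound 2 sits on the limit of > 100 nM in this assay, at which 1 of the 3 values shown sits, and so has no number. Compound 4 `CC(=O)c1ccc(OCCCCN2CCN(c3ccccn3)CC2)cc1` carries pyridin-2-yl in place of pyrimidin-2-yl on an amine nitrogen in a ring and keeps the acetyl. The nearest measured change, at the same place, is an at least 1.4-fold higher number from compound 1 to compound 2 (0.16 log units; that floor lies within the scatter) and stays within the scatter at its floor. The step of an at least 4.8-fold lower number from compound 2 to compound 3 (0.68 log units; beyond the scatter) lies at another place and bears little here. Compound 1 at 69 nM is the closest anchor. In this assay the expected step is an at least 1.4-fold lower number from compound 2 to compound 4 (0.15 log units; that floor lies within the scatter) and points to a lower number, possibly none beyond the scatter. The estimated value for compound 4 is 70 nM with an expected range of 25 nM to 180 nM in this read-out.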

Compound 4, half-maximal inhibitory concentration: 63.7 nM
Compound 4: the middle estimate sits 1.1-fold (0.04 log units) above what was measured; low and high end bracket the measured number.
By their numbers in this assay, from the lowest: compound 3; then compounds 4 and 1 (each within the scatter of the next). At a limit, above all of these: compound 2.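

With the acetyl kept, pyridin-2-yl and pyridin-3-yl on the amine nitrogen in a ring cannot be told apart in this assay: a 1.1-fold lower number from compound 1 to compound 4 (0.03 log units; within the scatter). Pyridin-2-yl in place of pyrimidin-2-yl reads as an at least 1.5-fold lower number from compound 2 to compound 4 (0.19 log units; that floor lies within the scatter), so the size of this step remains unsettled. Compound 2 holds a limit and no number: the limit of > 100 nM in this assay, at which 1 of the 4 values shown sits.

Open, from the compounds shown here alone, is whether a plain phenyl on the same nitrogen would fall in the same range as the two pyridines. Also open, going by these compounds, is how tert-butyl in place of acetyl, or a longer chain, would read with pyridin-2-yl.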